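Solubility limits and the step to compound 3

A few compounds are considered here, and "the series" means these few. Any claim that something is new, unique, unknown or untested is made for them only; others in the source may bear on it.

The series starts from compound 1 (`Cc1noc(-c2nc(C)c3c(c2N)C(=O)N(Cc2ccc(F)cc2)C3=O)n1`), which in a physicochemical assay for solubility, using the shake flask method, in simulated intestinal fluid, measured as kinetic solubility, with a stated time of 2 h, at 25 degrees C, at pH 6.5 (a higher number here means a more soluble compound, a lower number a less soluble compound), gives < 5000 nM as a limit and not a number. Compound 2 (`Cc1noc(-c2nc(C)c3c(c2N)C(=O)N(Cc2ccccc2C(F)(F)F)C3=O)n1`) gives < 5000 nM in this assay as a limit as well, so it has no number of its own. Both compounds rest on the limit of < 5000 nM in this assay, at which 2 of the 2 values shown sit, and nothing firmer is available. Going by the values given here, the one measured step is a step that the two limits leave unreadable from compound 1 to compound 2 and it offers no usable size.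

Compound 3 (`Cc1noc(-c2nc(C)c3c(c2N)C(=O)N(Cc2ccc(S(C)(=O)=O)cc2)C3=O)n1`) keeps the shared core. It carries 4-(methylsulfonyl)phenyl in place of 2-(trifluoromethyl)phenyl on a saturated chain carbon bound to an amide-type nitrogen in a ring. The measured step changed the same place, yet its size cannot be read, so it gives neither a magnitude nor a direction for this change. No step beyond the scatter is therefore expected in this assay. The expected step is a step that the limit leaves unreadable from compound 2 to compound 3 on this estimate. For compound 3 the estimated value is 4000 nM with an expected range from 1500 nM to 10000 nM and a further reading as a limit would be no surprise.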

Compound 3, solubility: < 5000 nM
Compound 3: a limit, no number; the forecaster's own chance of this, stated with the estimate: 70%; the middle value does not contradict the limit.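

Compound 3 also gives a limit and not a number in this assay, so the steps among compound 1, compound 2 and compound 3 cannot be read, and no new step follows: the limit of < 5000 nM in this assay, at which 3 of the 3 values shown sit.

The compounds shown leave open where the solubility of each lies, and whether changing the group on the saturated chain carbon shifts it at all.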